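Chain extension from compound 1 to compound 3

The source may hold more compounds than are shown below. What is called first, only, known or untested is meant among the compounds shown, and "the series" means these compounds.

Measured so far:
- Compound 1 `CCCCCC/C(=N\OCCC)c1cc(OC)c2c(c1OC)C(=O)C=CC2=O`; in a functional assay on A549 cells (Homo sapiens) for antiproliferative activity (a lower number here means that less compound is needed, a higher number that more compound is needed for the effect), compound 1 gives > 10 ug/mL, a limit of the assay.
- Compound 2 `CCCO/N=C/c1cc(OC)c2c(c1OC)C(=O)C=CC2=O`; in this assay compound 2 gives > 10 ug/mL, also a limit.

Compound 1 therefore stands only at a limit, not at a number; both values shown sit at the limit of > 10 ug/mL in this assay, at which 2 of the 2 values shown sit. Within the data shown here, no step between measured compounds is known, so no size can be read off. Compound 3 `CCCCCCCCCO/N=C(\CCCCCC)c1cc(OC)c2c(c1OC)C(=O)C=CC2=O` differs from compound 1 by hexyl in place of hydrogen on a saturated chain carbon, three bonds along the chain from an oxygen on an unsaturated carbon. With nothing measured beyond the limit, the change is expected to be none beyond the scatter, or small in either direction. Compound 3 is estimated at 15 ug/mL (range 5 ug/mL to 50 ug/mL). The step this estimate means is expected to be a step that the limit leaves unreadable from compound 1 to compound 3.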

Compound 3, concentration for half-maximal effect: > 10 ug/mL
Compound 3 was reported as a limit; the forecaster's own chance of this, stated with the estimate: 70%; the middle value does not contradict the limit.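

No step can be read from compound 1 to compound 3, since both stand only at a limit: the limit of > 10 ug/mL in this assay, at which 3 of the 3 values shown sit.

The compounds shown leave open whether any chain on the shared core gives a readable number in this assay.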